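A few compounds are considered here, and "the series" means these few. Any claim that something is new, unique, unknown or untested is made for them only; others in the source may bear on it.

Among the compounds with values here, compound 3 `CCCC(=O)c1ccc(OCCCCOc2cc(C(=O)O)ccc2OC)c(C)c1O` gives 64.2% in an assay on HEK293 cells for positive allosteric modulation of metabotropic glutamate receptor 3 (Rattus norvegicus), read by thallium flux, with a stated time of 2.5 min (on this read-out lower numbers stand for smaller maximal responses and higher numbers for larger maximal responses), the highest of the three numbers so far; compound 2 `Cc1c(OCCCCOc2ccccc2C(=O)O)ccc(C(=O)CC2CCCC2)c1O` gives 32.9% and compound 1 `Cc1c(OCCCCOc2ccc(C(=O)O)cc2Cl)ccc(C(=O)CC2CCCC2)c1O` gives 27.4%, both beyond the scatter below it. Within the data shown here, the one measured step, a number 5.5 percentage points higher from compound 1 to compound 2 (within the scatter), changes the carboxyphenyl end and leaves the carbonyl side chain untouched. Compound 4 `COc1ccc(C(=O)O)cc1OCCCCOc1ccc(C(=O)CC2CCCC2)c(O)c1C` differs from compound 3 by cyclopentyl in place of ethyl on a saturated chain carbon bound to a carbonyl carbon. Among the measured compounds shown here, no measured step varies this place; compounds 1 and 2 carry the (cyclopentylmethyl)carbonyl but also another carboxyphenyl end, so their lower values are only weak guidance. A modest downward step is expected, a number 14.2 percentage points lower from compound 3 to compound 4 (beyond the scatter), with wide uncertainty. Compound 4 is estimated at 50%, with a range from 25% to 75%.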

Compound 4, largest response reached (reported as percent of maximum), in percent of the reference or control that the assay uses: 67.6%
The estimate for compound 4 lay 17.6 percentage points below the measured number, within the range that was stated.
By their numbers in this assay, from the lowest: compounds 1 and 2 (each within the scatter of the next); then compounds 3 and 4 (each within the scatter of the next).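

At the saturated chain carbon bound to a carbonyl carbon, ethyl and cyclopentyl give matching maximal responses in this assay (a number 3.4 percentage points higher from compound 3 to compound 4 (within the scatter)), so cyclopentyl is tolerated at this place with the 5-carboxy-2-methoxyphenyl end. With the (cyclopentylmethyl)carbonyl held constant, the large steps lie at the carboxyphenyl end: 5-carboxy-2-methoxyphenyl outperforms 2-carboxyphenyl (a number 34.7 percentage points higher from compound 2 to compound 4 (beyond the scatter)) and 4-carboxy-2-chlorophenyl (a number 40.2 percentage points higher from compound 1 to compound 4 (beyond the scatter)). No available evidence accounts for these results.

Still open, as far as these compounds go, is whether a longer chain or an amine at this place would keep the response. The compounds shown also leave open whether the methoxy group of the carboxyphenyl end could be replaced by a hydroxyl group.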